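This account rests on a few compounds, and the source may have more. Where it says the series, first, only, none or still open, it means among the compounds named here.

In an assay on HeLa cells for displacement of a labelled ligand from 5-hydroxytryptamine receptor 6 (Homo sapiens) (on this read-out higher numbers stand for weaker inhibition and lower numbers for stronger inhibition), compound 3 `CSc1nc2cc(C)ccn2c(=N)c1S(=O)(=O)c1ccccc1` gives 41 nM, the highest of the three numbers recorded so far. Compound 1 `CSc1nc2ccccn2c(=N)c1S(=O)(=O)c1ccc(F)cc1` gives 22 nM, which lies within the scatter of the number for compound 3, while compound 2 `CNc1nc2ccccn2c(=N)c1S(=O)(=O)c1ccccc1` gives 2.4 nM, a lower number that sits beyond the scatter. Compound 4 `CCc1ccn2c(=N)c(S(=O)(=O)c3ccccc3)c(SC)nc2c1` has not yet been measured. It differs from compound 3 by methyl in place of hydrogen on a saturated chain carbon bound to an aromatic carbon, so that the methyl on the core becomes an ethyl. Among the compounds with values here, no pair of measured compounds differs in only this way, so nothing in the data fixes the size of this step. The expectation is a step that stays within the scatter, with no clear direction, a 1.1-fold higher number from compound 3 to compound 4 (0.04 log units; within the scatter). Compound 4 is accordingly estimated at 45 nM, with a range from 15 nM to 130 nM.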

Compound 4, half-maximal inhibitory concentration: 80 nM
Compound 4: middle estimate off by 1.8-fold (0.25 log units), on the low side, and the stated range covers the measured number.
By their numbers in this assay, from the lowest: compound 2; then compounds 1, 3 and 4 (each within the scatter of the next, the first and the last beyond it).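

In this assay, within the data shown here, the change from methyl to ethyl on the core gives a 2.0-fold higher number from compound 3 to compound 4 (0.29 log units; within the scatter) and so provides the first readable step at this place. The step stays within the scatter, so this single pair does not separate the ethyl from the methyl and fixes no direction for the change. No supporting evidence bears on this result. Going by these compounds, it remains open whether a propyl chain, a methoxy group or an amine at this place would move the number beyond the scatter.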